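Swapping the nitrile on the core for chlorine

The compounds below may be only part of what the source reports. "The series", "measured", "known", "first", "only" and "open" are said of these compounds alone.

Among the measured compounds shown here, the two compounds measured so far share a core and differ only on the outer aromatic ring. Compound 1 `N#Cc1ccc(S(=O)(=O)Nc2cccc3c(C#N)c[nH]c23)cc1` gives 33 ug/mL in a functional assay on KB cells (nasopharynx, Homo sapiens) for antiproliferative activity; a lower number here means a stronger inhibitor, a higher number a weaker inhibitor. Compound 2 `CS(=O)(=O)Nc1ccc(S(=O)(=O)Nc2cccc3c(C#N)c[nH]c23)cc1` gives 15 ug/mL in this assay, the lowest of the two numbers; the step of a 2.2-fold lower number from compound 1 to compound 2 (0.34 log units; beyond the scatter) puts methanesulfonamido in place of cyano on an aromatic carbon. Compound 3 `CS(=O)(=O)Nc1ccc(S(=O)(=O)Nc2cccc3c(Cl)c[nH]c23)cc1` keeps that methanesulfonamido and instead alters the core: chloro in place of cyano on an aromatic carbon on an aromatic carbon of a five-membered aromatic ring with one nitrogen, part of a fused system of two rings. For the measured compounds named here, no measured step touches this position, so the only step known, from compound 1 to compound 2, bears on it merely as a sign that single exchanges here have so far shifted numbers modestly. The expected step of a 1.3-fold higher number from compound 2 to compound 3 (0.12 log units; within the scatter) is therefore small and of uncertain direction. Compound 3 is estimated at 20 ug/mL, within 8 ug/mL to 50 ug/mL.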

Compound 3, half-maximal inhibitory concentration: 12 ug/mL
Estimate against measurement, compound 3: 1.7-fold (0.22 log units) above; the measured number falls inside the stated range.
By their numbers in this assay, from the lowest: compounds 3 and 2 (each within the scatter of the next); then compound 1.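

Among the compounds shown here, this is the first measured change at this position, on the five-membered aromatic ring two ring bonds from the ring nitrogen, and in this assay putting chloro in place of cyano gives a 1.3-fold lower number from compound 2 to compound 3 (0.10 log units; within the scatter) and so stays within the usual scatter. With the methanesulfonamido group held constant, the nitrile can therefore be exchanged for a single chlorine atom with no change that this measurement can separate from repeat-to-repeat variation. Nothing available explains why these two groups give such similar numbers here.

As far as these compounds go, whether a larger or very different group at this position, such as an amine, a carboxylic acid or a longer carbon chain, would also leave the number unchanged remains open. From the compounds shown here alone, it is also open whether chloro and cyano would give similar numbers with the cyano-bearing outer ring of compound 1.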